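From cyano to pent-1-yn-1-yl in compound 3

The source may report more compounds than this note shows. Statements on the series, on what has been measured and on what is new or still open speak of the compounds shown alone.

Compound 1 `O=c1[nH]c(=O)n([C@H]2C[C@H](O)[C@@H](CO)O2)cc1/C=C/I`: 63900 nM
Compound 2 `N#Cc1cn([C@H]2C[C@H](O)[C@@H](CO)O2)c(=O)[nH]c1=O`: > 200000 nM (a limit)

In an ADME assay on L1210/0 cells (Mus musculus) for cytotoxicity, with a stated time of 48 h (a higher number here means a weaker inhibitor, a lower number a stronger inhibitor), compound 2 gives only a limit, > 200000 nM, which is the limit of > 200000 nM in this assay, at which 1 of the 2 values shown sits. Compound 3 `CCCC#Cc1cn([C@H]2C[C@H](O)[C@@H](CO)O2)c(=O)[nH]c1=O` carries pent-1-yn-1-yl in place of cyano on an aromatic carbon. For the measured compounds named here, one measured step bears on this change, an at least 3.1-fold higher number from compound 1 to compound 2 (0.49 log units; beyond the scatter), and there the arrival of cyano went with a higher number. Losing cyano is therefore expected to give a modestly lower number in this assay. The estimated step is an at least 2.0-fold lower number from compound 2 to compound 3 (0.30 log units; that floor lies within the scatter). Compound 3 is estimated at 100000 nM, with an expected range from 30000 nM to 200000 nM.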

Compound 3, half-maximal inhibitory concentration: > 200000 nM
Compound 3 was reported as a limit; the forecaster's own chance of this, stated with the estimate: 35%; at least 2.0-fold (0.30 log units) between middle value and limit.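

Compound 3 is also reported only as a limit, so a second group in place of 2-iodoethenyl on this aromatic carbon, here pent-1-yn-1-yl, gives an at least 3.1-fold higher number from compound 1 to compound 3 (0.49 log units; beyond the scatter) in this assay. The step between compound 2 and compound 3 cannot be read, and the longer chain shows no readable difference from cyano, with most of the series now at the same ceiling: the limit of > 200000 nM in this assay, at which 2 of the 3 values shown sit.

The compounds shown leave open whether an amine or an ethyl chain on this carbon would give a readable value. They also leave open whether the iodine or the double bond of 2-iodoethenyl goes with the lower number of compound 1.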